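This account rests on a few compounds, and the source may have more. Where it says the series, first, only, none or still open, it means among the compounds named here.

Measured so far in a functional assay on MV4-11 cells (Homo sapiens) for inhibition, with a stated time of 72 h; a higher number here means a weaker inhibitor, a lower number a stronger inhibitor:
- compound 1 `CC(C)N(Cc1ccc(C(=O)NO)cc1)S(=O)(=O)c1c(F)c(F)c(F)c(F)c1F`: 510 nM
- compound 2 `CC(C)N(Cc1ccc(C(=O)NO)cc1)Cc1cc(F)c(F)c(F)c1F`: 7430 nM

Of these two numbers, compound 1 holds the lower, and the gap to compound 2 lies beyond the scatter. Compound 3 `CC(C)N(Cc1ccc(C(=O)NO)cc1)S(=O)(=O)c1cc(F)c(F)c(F)c1F` differs from compound 1 in one place, with hydrogen in place of fluoro on an aromatic carbon. Among the compounds with values here, no measured pair shows this change, so the expectation is cautious: no step beyond the scatter in this assay, and hence no clear direction. The expected result is a 1.2-fold higher number from compound 1 to compound 3 (0.07 log units; within the scatter). Compound 3 is estimated at 600 nM, with an expected range from 250 nM to 1400 nM.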

Compound 3, half-maximal inhibitory concentration: 1190 nM
Beside the measured number, compound 3's estimate is 2.0-fold (0.30 log units) below it; the range from low to high includes it.
By their numbers in this assay, from the lowest: compound 1; then compound 3; then compound 2.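

In this assay hydrogen in place of the fluoro ortho to a large group gives a 2.3-fold higher number from compound 1 to compound 3 (0.37 log units; beyond the scatter) as a modest step. Within the data shown here, this is the first sign that a single-atom change at this aromatic carbon can move the number beyond the scatter, which the earlier compounds, differing in more than one place, could not show. The data offer no explanation for this step.

Going by these compounds, whether chloro, methoxy or an amine at this carbon would give a similar step remains open. So does whether removing the fluoro groups meta or para to it would count as much.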